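Notes on compound 4: one methoxy removed

The source may report more compounds than this note shows. Statements on the series, on what has been measured and on what is new or still open speak of the compounds shown alone.

Compound 1 `COc1cc(-c2cc(/C=C/C(=O)c3ccc(N)cc3)[nH]n2)cc(OC)c1OC` gives -35% in a functional assay on HOP-92 cells (Homo sapiens) for cytotoxicity, read by sulforhodamine B assay, with a stated time of 48 h, tested at 100 uM (a higher number here means a weaker effect of the compound at the concentration tested, a lower number a stronger effect), the highest of the three numbers obtained so far. Compound 3 `COc1ccc(C(=O)/C=C/c2cc(-c3cc(OC)c(OC)c(OC)c3)n[nH]2)cc1` gives -36% in this assay, and compound 2 `COc1cc(-c2cc(/C=C/C(=O)c3ccc(Cl)c(Cl)c3)[nH]n2)cc(OC)c1OC` gives -56%. The measured steps all concern the group on the carbonyl carbon: a number 21 percentage points lower from compound 1 to compound 2 (beyond the scatter), a number 1 percentage points lower from compound 1 to compound 3 (within the scatter) and a number 20 percentage points higher from compound 2 to compound 3 (beyond the scatter). Compound 4 `COc1ccc(-c2cc(/C=C/C(=O)c3ccc(N)cc3)[nH]n2)cc1OC` differs from compound 1 elsewhere in the shared core: hydrogen in place of methoxy on an aromatic carbon. Among the compounds with values here, none of the measured steps touches that part of the molecule, so there is no direct precedent for this change. Within the data shown here, the only step within the scatter, a number 1 percentage points lower from compound 1 to compound 3 (within the scatter), shows that a change of a group on the carbonyl carbon can leave the read-out where it was, but it is a different place and carries no weight for the methoxy. With nothing to anchor a direction, the expectation is a step of no change at the digits printed from compound 1 to compound 4 (within the scatter), most likely nothing beyond the scatter and with the range kept wide in both directions. Compound 4 is therefore expected to give -35% in this assay, within a range of -55% to -12%.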

Compound 4, a percentage reported as activity, at one concentration (the size of the read-out at that concentration, not a potency): -81%
For compound 4 the middle estimate is 46 percentage points above the measured one; the whole stated range lies above it.
By their numbers in this assay, from the lowest: compound 4; then compound 2; then compounds 3 and 1 (each within the scatter of the next).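

Within the data shown here, the six-membered aromatic ring of carbon only that carries the methoxy groups, a part of the molecule no earlier step touched, proves to be a sensitive place in this assay: hydrogen in place of methoxy gives a number 46 percentage points lower from compound 1 to compound 4 (beyond the scatter) and counts as a large step, whereas the two steps beyond the scatter at the carbonyl carbon (a number 21 percentage points lower from compound 1 to compound 2 (beyond the scatter) and a number 20 percentage points higher from compound 2 to compound 3 (beyond the scatter)) are modest. The change is small in itself, since only a methoxy of 2 heavy atoms leaves, from a place ortho to one methoxy group and meta to another, so the read-out here does not depend on the size of the change alone. Nothing available bears on why removing this methoxy shifts the read-out so far.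

Still open, from the compounds shown here alone, is whether the same change gives a step of this size with 3,4-dichlorophenyl or 4-methoxyphenyl on the carbonyl carbon rather than 4-aminophenyl. A hydroxy group, a fluorine atom or an ethoxy group at this place would show whether the step follows from the loss of the methoxy or from the hydrogen that enters.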